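The compounds below may be only part of what the source reports. "The series", "measured", "known", "first", "only" and "open" are said of these compounds alone.

Measured compounds:
compound 1, `O=C1/C(=C/c2ccccc2F)CCc2ccccc21`, 20800 nM in a functional assay on CCRF-CEM cells (Homo sapiens) for inhibition; a higher number here means a weaker inhibitor, a lower number a stronger inhibitor
compound 2, `O=C1/C(=C/c2ccccc2F)Cc2ccccc21`, 47100 nM in this assay
compound 3, `O=C1/C(=C/c2ccccc2[N+](=O)[O-])CCc2ccccc21`, 7220 nM in this assay

Compound 2 gives the highest number of the three; the difference between its core and the core of compound 1 is not broken down here. Compound 1 and compound 3 share a core and differ by nitro in place of fluoro on an aromatic carbon. That change gives a 2.9-fold lower number from compound 1 to compound 3 (0.46 log units; beyond the scatter) in this assay.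

Compound 4, `O=C1/C(=C/c2ccccc2[N+](=O)[O-])Cc2ccccc21`, is not yet measured. Among the measured compounds shown here, it differs from compound 2 by nitro in place of fluoro on an aromatic carbon, which is the same change as the one from compound 1 to compound 3, at the same place. Because compound 1 to compound 3 gave a 2.9-fold lower number from compound 1 to compound 3 (0.46 log units; beyond the scatter), a step of about the same size is expected on the core of compound 2, namely a 2.9-fold lower number from compound 2 to compound 4 (0.47 log units; beyond the scatter). Compound 4 is therefore estimated at 16000 nM in this assay, within 7000 nM to 36000 nM.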

Compound 4, half-maximal inhibitory concentration: 3530 nM
Beside the measured number, compound 4's estimate is 4.5-fold (0.66 log units) above it; the measured number lies below the stated range.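

On the core of compound 2, nitro in place of fluoro on an aromatic carbon gives a 13-fold lower number from compound 2 to compound 4 (1.13 log units; beyond the scatter) in this assay. Among the compounds shown here, the direction of the step carries over between the two cores, but its size does not: the same change on two cores in this assay, a 2.9-fold lower number (0.46 log units; beyond the scatter) from compound 1 to compound 3 and a 13-fold lower number (1.13 log units; beyond the scatter) from compound 2 to compound 4, 4.6-fold (0.67 log units) apart, beyond the scatter of two such steps With only two cores and this single exchange of groups, the result shows that the size of the step depends on the core in these compounds, but it does not show why, nor how large the step would be on any further core.

The compounds shown leave open whether other groups at the same place, such as an amine, a nitrile or a carboxylic acid, would also give steps that differ between these two cores.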